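Swapping the methyl(phenyl)amino group on the shared core

The compounds below may be only part of what the source reports. "The series", "measured", "known", "first", "only" and "open" are said of these compounds alone.

Measured so far in a functional assay on Huh-7 cells (Homo sapiens) for cytotoxicity, read by MTT assay, with a stated time of 3 days; on this read-out lower numbers stand for higher toxicity in this test and higher numbers for lower toxicity in this test:
compound 1 `CN(Cc1ncnc2c1ncn2[C@@H]1O[C@H](CO)[C@@H](O)[C@H]1O)c1ccccc1`: 21000 nM
compound 2 `OC[C@H]1O[C@@H](n2cnc3c(CSCc4ccccc4)ncnc32)[C@H](O)[C@@H]1O`: > 100000 nM, a limit of the assay rather than a number
compound 3 `OC[C@H]1O[C@@H](n2cnc3c(CN4CCCCC4)ncnc32)[C@H](O)[C@@H]1O`: 87000 nM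

Compound 1 has the lowest of the two numbers; compound 3 sits nearest, with a 4.1-fold higher number from compound 1 to compound 3 (0.62 log units; beyond the scatter). Compound 2 gives only a limit (the limit of > 100000 nM in this assay, at which 1 of the 3 values shown sits), so the step there reads an at least 4.7-fold higher number from compound 1 to compound 2 (0.67 log units; beyond the scatter). Compound 4 `CC(C)N(Cc1ncnc2c1ncn2[C@@H]1O[C@H](CO)[C@@H](O)[C@H]1O)C(C)C` is not yet measured and differs from compound 1 by diisopropylamino in place of methyl(phenyl)amino on a saturated chain carbon bound to an aromatic carbon. Both measured changes at this place raised the number beyond the scatter, so a modest rise is expected for compound 4 as well in this assay. Compound 4 is expected to give 75000 nM, between 30000 nM and 160000 nM, a step of a 3.6-fold higher number from compound 1 to compound 4 (0.55 log units; beyond the scatter).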

Compound 4, half-maximal cytotoxic concentration: 18000 nM
The estimate for compound 4 lay 4.2-fold (0.62 log units) above the measured number; measured number outside the range, below it.
By their numbers in this assay, from the lowest: compounds 4 and 1 (each within the scatter of the next); then compound 3. At a limit, above all of these: compound 2.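

In this assay the replacement of methyl(phenyl)amino by diisopropylamino gives a 1.2-fold lower number from compound 1 to compound 4 (0.07 log units; within the scatter) so losing the aromatic ring does not by itself raise the number at this position. Two groups without an aromatic ring are now separated, with a 4.8-fold lower number from compound 3 to compound 4 (0.68 log units; beyond the scatter) so the outcome depends on which amino group enters. Against benzylsulfanyl the step reads an at least 5.5-fold lower number from compound 2 to compound 4 (0.74 log units; beyond the scatter) and compound 2 stands at a limit of the assay, not a number: the limit of > 100000 nM in this assay, at which 1 of the 4 values shown sits.

Open, on these data alone, is where a smaller open-chain amine such as dimethylamino, or a morpholin-4-yl group, would fall relative to compound 3 and compound 4.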